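Acetyl to Dimethylamino: An Untested Analogue of Compound 1

This account rests on a few compounds, and the source may have more. Where it says the series, first, only, none or still open, it means among the compounds named here.

Measured so far:
compound 1, `COc1cc(C)cc(-c2c(-c3ccnc(-c4ccc(C(C)=O)cc4)c3)cnn2CC#N)c1`, 87%
compound 2, `COc1cc(C)cc(-c2nn(CC#N)cc2-c2ccc(-c3cccc(C(C)=O)c3)nc2)c1`, 69%
compound 3, `Cc1cc(O)cc(-c2nn(CC#N)cc2-c2ccnc(-c3ccc(Oc4ccccc4)cc3)c2)c1`, 91%

In a functional assay on HCT-15 cells (Homo sapiens) for cytotoxicity, read by sulforhodamine B assay, with a stated time of 48 h, tested at 100 nM (on this read-out lower numbers stand for a stronger effect and higher numbers for a weaker effect at the one concentration tested), compound 1 gives 87%. Compound 3 gives 91%, a number within the scatter of that of compound 1, so no order between the two can be read. Compound 2 gives 69%, a lower number, and that gap lies beyond the scatter. Compound 4, `COc1cc(C)cc(-c2c(-c3ccnc(-c4ccc(N(C)C)cc4)c3)cnn2CC#N)c1`, differs from compound 1 in one place: dimethylamino in place of acetyl on an aromatic carbon. Cut one bond further out, the change reads 4-acetylphenyl to 4-(dimethylamino)phenyl, on an aromatic carbon para to a large group. Going by the values given here, no measured pair shows this change, so nothing in the data fixes its size or direction. All three measured numbers sit at the weak end of this read-out, and the exchange of one small group for another gives no ground for a large move. The step of a number 2 percentage points lower from compound 1 to compound 4 (within the scatter) is therefore expected to stay within the scatter. Compound 4 is estimated at 85%, with a range from 65% to 100%.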

Compound 4, a percentage reported as activity, at one concentration (the size of the read-out at that concentration, not a potency): 14%
The estimate for compound 4 lay 71 percentage points above the measured number, and the stated range ends above it.
By their numbers in this assay, from the lowest: compound 4; then compound 2; then compounds 1 and 3 (each within the scatter of the next).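

In this assay, going by these compounds alone, the exchange of acetyl for dimethylamino gave a number 73 percentage points lower from compound 1 to compound 4 (beyond the scatter), the first step between compounds differing in one place. It shows that this position, on an aromatic carbon para to a large group, is not indifferent to what it carries. Acetyl and dimethylamino match in heavy-atom count, hydrogen-bond donors and acceptors and net charge, yet they lie far apart at the one concentration tested. Nothing at hand accounts for this difference.

The compounds shown leave open whether a primary amine, a methoxy group or a pyrrolidine ring at this place would give a similar number, or whether dimethylamino is needed. They also leave open whether the same exchange would have a similar effect on the core of compound 2.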